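Shortening the piperidine-bearing chain on an isoindolinone acid

The compounds below may be only part of what the source reports. "The series", "measured", "known", "first", "only" and "open" are said of these compounds alone.

Compound 1 `CC(CC(=O)O)N1Cc2ccc(NC(=O)CC3CCNCC3)cc2C1=O` gives 2700 nM in a functional assay on a cell-free system (Platelet, plasma, Homo sapiens) for inhibition; on this read-out higher numbers stand for weaker inhibition and lower numbers for stronger inhibition.
Compound 2 `O=C(O)CCCN1Cc2ccc(NC(=O)CCCC3CCNCC3)cc2C1=O` gives 51000 nM in this assay.

Of the two measured compounds, compound 2 stands with the higher number, so it is the weaker inhibitor of the pair, and the gap to compound 1 lies well beyond the scatter. Compound 3 `O=C(O)CCCN1Cc2ccc(NC(=O)CC3CCNCC3)cc2C1=O` has not yet been measured in this assay. It differs from compound 2 in one place: piperidin-4-yl in place of 2-(piperidin-4-yl)ethyl on a saturated chain carbon bound to a carbonyl carbon. With this change the amide portion of compound 3 matches that of compound 1, and the two then differ only in the acid-bearing chain on the ring nitrogen. Because compound 1 gives 2700 nM, the step of a 13-fold lower number from compound 2 to compound 3 (1.11 log units; beyond the scatter) is expected to be a large drop in the number, well beyond the scatter, toward stronger inhibition. Compound 3 is therefore estimated at 4000 nM, with a plausible range from 1500 nM to 12000 nM.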

Compound 3, half-maximal inhibitory concentration: 1800 nM
Compound 3: middle estimate off by 2.2-fold (0.35 log units), on the high side; the measured number falls inside the stated range.
By their numbers in this assay, from the lowest: compounds 3 and 1 (each within the scatter of the next); then compound 2.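

In this assay, going by these compounds alone, piperidin-4-yl in place of 2-(piperidin-4-yl)ethyl on a saturated chain carbon bound to a carbonyl carbon gives a 28-fold lower number from compound 2 to compound 3 (1.45 log units; beyond the scatter), the first reading of this position with only one place changed. With the piperidine side held the same, 3-carboxypropyl in place of 1-(carboxymethyl)ethyl on an amide-type nitrogen in a ring gives a 1.5-fold lower number from compound 1 to compound 3 (0.18 log units; within the scatter), so these two acid-bearing chains are not distinguished on this read-out. Nothing available gives a reason for either step.

The compounds shown leave open how the number behaves for a chain of intermediate length or for a piperidine ring bound directly to the amide carbonyl. They also leave open whether an open-chain amine could replace the piperidine, or an ester the carboxylic acid.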